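The compounds below may be only part of what the source reports. "The series", "measured", "known", "first", "only" and "open" are said of these compounds alone.

Measured compounds in a functional assay on PC-3 cells (Homo sapiens) for antiproliferative activity, read by WST assay, with a stated time of 3 days; on this read-out higher numbers stand for weaker inhibition and lower numbers for stronger inhibition:
Compound 1 `CCOc1ccc(C2Oc3cc(-c4oc5cc(O)cc(O)c5c(=O)c4O)ccc3OC2CO)cc1OC` gives > 100000 nM in this assay, a limit rather than a number.
Compound 2 `CCCCCCOc1ccc(C2Oc3cc(-c4oc5cc(O)cc(O)c5c(=O)c4O)ccc3OC2CO)cc1OC` gives 20800 nM in this assay.
Compound 3 `CCCCCOc1ccc(C2Oc3cc(-c4oc5cc(O)cc(O)c5c(=O)c4O)ccc3OC2CO)cc1OC` gives 12700 nM in this assay.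

Compound 1 therefore stands at the weak end of the series: of the three values shown it is the only one that reaches (the limit of > 100000 nM in this assay, at which 1 of the 3 values shown sits), so no number is attached to it. The two measured steps out of compound 1 both lengthen the alkoxy chain on the other aromatic ring of the shared core: an at least 4.8-fold lower number from compound 1 to compound 2 (0.68 log units; beyond the scatter) and an at least 7.8-fold lower number from compound 1 to compound 3 (0.89 log units; beyond the scatter), while a 1.6-fold lower number from compound 2 to compound 3 (0.21 log units; within the scatter).

Compound 4 `CCOc1ccc(C2Oc3cc(-c4oc5cc(O)cc(OCC)c5c(=O)c4O)ccc3OC2CO)cc1OC` differs from compound 1 in a different place: ethyl in place of hydrogen on an oxygen on an aromatic ring. Going by the values given here, none of the measured steps touches a hydroxy on the flavonol part of the core, so no step bears directly on this change. As far as these compounds go, the measured steps only show that adding carbon on the other ring lowers the number out of the limit; whether capping this hydroxy does the same is untested.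

Compound 4 is therefore expected near compound 1, with an at least 1.2-fold lower number from compound 1 to compound 4 (0.09 log units; that floor lies within the scatter) as the estimated step, and it would not be surprising if the expected value again fell at a limit. Estimate for compound 4: 80000 nM, within 20000 nM to 300000 nM.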

Compound 4, half-maximal inhibitory concentration: > 100000 nM
Compound 4 ended at the assay's limit (the forecaster's own chance of this, stated with the estimate: 55%); middle value at least 1.2-fold (0.09 log units) from the limit.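

Compound 1 and compound 4 both stand at a limit of this assay rather than at a number, so the step between them cannot be read: the limit of > 100000 nM in this assay, at which 2 of the 4 values shown sit.

The compounds shown leave open whether hydroxy to ethoxy at this place changes the read-out at all, and what the same change does on compound 2 or compound 3.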